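This account rests on a few compounds, and the source may have more. Where it says the series, first, only, none or still open, it means among the compounds named here.

Measured compounds:
compound 1, `CCCCc1cnc(CCCc2ccc(-c3ccccc3C(=O)O)cc2)[nH]1`, giving 382 nM;
compound 2, `O=C(O)c1ccccc1-c1ccc(CCc2ncc(Cc3cccc(F)c3)[nH]2)cc1`, giving 7.9 nM.

Of the compounds shown here, two have been measured in an in vitro functional assay on cells for agonist activity at Bombesin receptor subtype-3 (Mus musculus), read by luminescence and calcium flux; a lower number here means that less compound is needed, a higher number that more compound is needed for the effect. Compound 2 has the lower of the two numbers, and compound 1 has the higher; the gap between them lies well beyond the usual scatter of repeated measurements, so on these two numbers compound 2 is the more potent of the pair.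

The next compound, compound 3, `O=C(O)c1ccccc1-c1ccc(CCc2ncc(Cc3ccccc3)[nH]2)cc1`, keeps the whole of compound 2 except one point: hydrogen in place of fluoro on an aromatic carbon. The change is a hydrogen in place of fluoro on an aromatic carbon, meta to a large group, so 3-fluorobenzyl becomes benzyl.

Among the measured compounds shown here, no measured pair isolates this change, so nothing in the data sets its size. A single fluorine removed from a benzyl group is a small change, and the author expects at most a modest step in this assay from compound 2 to compound 3, most likely a slight rise in the number, possibly none beyond the scatter; the expected step is a 1.5-fold higher number from compound 2 to compound 3 (0.18 log units; within the scatter). Compound 3 is therefore estimated at 12 nM, within a range from 4 nM to 40 nM.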

Compound 3, half-maximal effective concentration: 11 nM
Beside the measured number, compound 3's estimate is 1.1-fold (0.04 log units) above it, within the range that was stated.
By their numbers in this assay, from the lowest: compounds 2 and 3 (each within the scatter of the next); then compound 1.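

Among the compounds shown here, compound 2 and compound 3 form the first pair that isolates one place, and in this assay the exchange of 3-fluorobenzyl for benzyl gives a 1.4-fold higher number from compound 2 to compound 3 (0.14 log units; within the scatter). This position therefore tolerates the loss of fluoro in this assay: compound 3 gives 11 nM without any halogen on that six-membered aromatic ring, so the fluorine is not needed for a low number here. No other kind of measurement bears on this result, so the data offer no explanation for it.

As far as these compounds go, whether the same place would also accept a larger or differently built group, such as chloro, methoxy, trifluoromethyl or an amine, remains open, since a single exchange of fluoro for hydrogen shows only that these two substituents read alike. Compound 1 differs from both compound 2 and compound 3 in more than one place, so its distance from them cannot be assigned to any one feature, and the separate contributions of its butyl chain and its longer linker remain unread.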